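From methoxy to an amide chain on compound 1

The compounds below may be only part of what the source reports. "The series", "measured", "known", "first", "only" and "open" are said of these compounds alone.

Measured in an in vivo ADME assay on the whole organism for pharmacokinetics, with Rattus norvegicus as the target; on this read-out higher numbers stand for fast clearance and lower numbers for slow clearance:
- compound 1 `COc1ccc2c(c1)CC(c1nc3ccc(-c4ccnc(N)n4)cc3[nH]1)CO2`: 17 mL/min/kg
- compound 2 `Nc1nccc(-c2ccc3nc(C4COc5c(cccc5C(=O)NC5CC5)C4)[nH]c3c2)n1`: 29 mL/min/kg

In this assay, compound 1 gives 17 mL/min/kg and compound 2 gives 29 mL/min/kg. These two values lie within the usual scatter of each other, so compound 1 cannot be separated from compound 2 on these numbers.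

Compound 3 `CN(C)CCCNC(=O)c1ccc2c(c1)CC(c1nc3ccc(-c4ccnc(N)n4)cc3[nH]1)CO2` keeps the core of compound 1 and changes one group, with (3-(dimethylamino)propyl)carbamoyl in place of methoxy on an aromatic carbon. Among the measured compounds shown here, no measured pair isolates a change of this kind, so the data offer no direct guide and any forecast remains uncertain. A modest rise in this assay is expected, about the size of the scatter, and a step beyond it cannot be excluded. The expected step is a 2.1-fold higher number from compound 1 to compound 3 (0.31 log units; beyond the scatter). For compound 3 the estimated value is 35 mL/min/kg, with an expected range of 15 mL/min/kg to 75 mL/min/kg.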

Compound 3, clearance: 27 mL/min/kg
For compound 3 the middle estimate is 1.3-fold (0.11 log units) above the measured one, and the stated range covers the measured number.
By their numbers in this assay, from the lowest: compounds 1, 3 and 2 (each within the scatter of the next).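

In this assay, putting (3-(dimethylamino)propyl)carbamoyl in place of methoxy on this aromatic carbon gives a 1.6-fold higher number from compound 1 to compound 3 (0.20 log units; within the scatter), so the two compounds cannot be separated on this read-out. The result shows that this position, meta to one fused ring and para to another, can carry a far larger chain, with an added hydrogen-bond donor, without a step beyond the scatter. Nothing available explains why the number stays within the scatter.

The compounds shown leave open whether a carboxylic acid, a primary amide or a longer chain ending in a dimethylamino group on the same carbon would also stay within the scatter of compound 1. They also do not separate the part played by the amide from that of the dimethylamino end of the chain.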